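Moving the chlorine on the chlorophenyl group

The compounds below may be only part of what the source reports. "The series", "measured", "known", "first", "only" and "open" are said of these compounds alone.

Compound 1 `Oc1ccc(-c2cc(-c3ccc(Cl)cc3)nc(-c3cccs3)c2)cc1` gives 4520 nM
Compound 2 `Oc1ccc(-c2cc(-c3ccc(Cl)cc3)nc(-c3ccsc3)c2)cc1` gives 4860 nM
Compound 3 `Oc1cccc(-c2cc(-c3ccc(Cl)cc3)nc(-c3ccsc3)c2)c1` gives 11200 nM

In an ADME assay on HEK293 cells (Homo sapiens) for cytotoxicity, read by CCK-8 assay and cell counting, with a stated time of 2 days (on this read-out higher numbers stand for weaker inhibition and lower numbers for stronger inhibition), the steps run a 1.1-fold higher number from compound 1 to compound 2 (0.03 log units; within the scatter) and a 2.3-fold higher number from compound 2 to compound 3 (0.36 log units; beyond the scatter) and leave compound 2 at the low end of the three numbers, level with compound 1. Compound 4 `Oc1ccc(-c2cc(-c3ccsc3)nc(-c3cccc(Cl)c3)c2)cc1` differs from compound 2 by 3-chlorophenyl in place of 4-chlorophenyl on an aromatic carbon on an aromatic carbon next to the ring nitrogen. Within the data shown here, no measured step moves the chlorine. The nearest parallel is compound 3, where 3-hydroxyphenyl replaced 4-hydroxyphenyl, a modest step of a 2.3-fold higher number from compound 2 to compound 3 (0.36 log units; beyond the scatter) in this assay while the thiophene exchange stayed within the scatter. Only a small rise is therefore expected, with a 1.5-fold higher number from compound 2 to compound 4 (0.19 log units; within the scatter) as the estimated step. In this assay compound 4 is expected near 7500 nM with 3500 nM to 17000 nM as its estimated range.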

Compound 4, half-maximal inhibitory concentration: 2670 nM
Beside the measured number, compound 4's estimate is 2.8-fold (0.45 log units) above it, outside the stated range (below it).
By their numbers in this assay, from the lowest: compounds 4, 1 and 2 (each within the scatter of the next); then compound 3.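

In this assay, shifting the chlorine from the 4-chlorophenyl to the 3-chlorophenyl arrangement gives a 1.8-fold lower number from compound 2 to compound 4 (0.26 log units; within the scatter) and so leaves the number unresolved from that of compound 2. At this position next to the ring nitrogen, the chlorine's placement therefore reads differently from the hydroxyl shift, which gave a 2.3-fold higher number from compound 2 to compound 3 (0.36 log units; beyond the scatter) in the same assay. Nothing available explains this difference. From the compounds shown here alone, it remains open whether the chlorine shift would read the same alongside the 3-hydroxyphenyl group of compound 3, and how an amine or a carboxylic acid in place of the chlorine would fare.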